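A Second Chloro Group on Compound 1

The source may report more compounds than this note shows. Statements on the series, on what has been measured and on what is new or still open speak of the compounds shown alone.

Measured in a functional assay (Homo sapiens) for inhibition, read by luminescence, with a stated time of 72 h; a higher number here means a weaker inhibitor, a lower number a stronger inhibitor:
- compound 1 `CSc1nccc(N2CCC(N(C)Cc3ccccc3Cl)CC2)n1`: 1700 nM
- compound 2 `CSc1nccc(N2CCC(N(C)Cc3ccc(C#N)cc3)CC2)n1`: 1470 nM

With only these two values known, there is no real ranking, as the pair stands level: a 1.2-fold lower number from compound 1 to compound 2 (0.06 log units; within the scatter). That single measured step swapped one substituted phenyl group for another and left the number within the scatter.

Compound 3 `CSc1nccc(N2CCC(N(C)Cc3c(Cl)cccc3Cl)CC2)n1` alters compound 1 in one place: chloro in place of hydrogen on an aromatic carbon. This puts chloro in place of hydrogen on an aromatic carbon, turning 2-chlorophenyl into 2,6-dichlorophenyl. Among the measured compounds shown here, no measured step adds a second chloro group, so the evidence is thin. For the measured compounds named here, the only guide is the step above, which touched the same part of the molecule, so no step beyond the scatter is expected in this assay, in either direction.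

For compound 3 the estimated value is 1500 nM, with an expected range of 600 nM to 3500 nM. This expected value amounts to a 1.1-fold lower number from compound 1 to compound 3 (0.05 log units; within the scatter).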

Compound 3, half-maximal inhibitory concentration: 700 nM
The estimate for compound 3 lay 2.1-fold (0.33 log units) above the measured number; the measured number falls inside the stated range.
By their numbers in this assay, from the lowest: compound 3; then compounds 2 and 1 (each within the scatter of the next).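

Turning 2-chlorophenyl into 2,6-dichlorophenyl gives the first step beyond the scatter in this assay, with a 2.4-fold lower number from compound 1 to compound 3 (0.39 log units; beyond the scatter) as a modest but readable change, so a single added chloro atom on this aromatic carbon can move the number where the earlier swap of one substituted phenyl group for another did not. Compound 3 also differs from the 4-cyanophenyl compound, with a 2.1-fold lower number from compound 2 to compound 3 (0.32 log units; beyond the scatter) on record, so it stands apart from both earlier compounds, which remain level with each other. Nothing available explains why this added chloro group goes with a lower number.

The compounds shown leave open whether another group on this same carbon, such as methyl, methoxy or an amine, would give a similar step. They also leave open how much further the number can fall with changes at this position.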